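The compounds below may be only part of what the source reports. "The series", "measured", "known", "first", "only" and "open" are said of these compounds alone.

Of the compounds shown here, three sharing one core have been measured in an assay on CHO-K1 cells for antagonist activity at transient receptor potential cation channel subfamily V member 1 (Homo sapiens), read by FLIPR and calcium flux, with a stated time of 6 min; a higher number here means a weaker inhibitor, a lower number a stronger inhibitor. Compound 1 `O=C(NCc1cc(C(F)(F)F)nn1-c1cccc(Cl)c1)Nc1cccc2[nH]ncc12` gives 0.9 nM, compound 2 `O=C(NCc1cc(C(F)(F)F)nn1-c1cccc(C(F)(F)F)c1)Nc1cccc2[nH]ncc12` gives 1.3 nM, and compound 3 `O=C(NCc1cc(C(F)(F)F)nn1-c1ccc(Cl)cc1)Nc1cccc2[nH]ncc12` gives 2.5 nM. Compound 3 thus shows the highest of the three numbers, but the step of a 1.9-fold higher number from compound 2 to compound 3 (0.28 log units; within the scatter) lies within the scatter, while the step of a 2.8-fold higher number from compound 1 to compound 3 (0.44 log units; beyond the scatter) is beyond it and counts as modest.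

Compound 4 `O=C(NCc1cc(C(F)(F)F)nn1-c1ccc(C(F)(F)F)cc1)Nc1cccc2[nH]ncc12` has not yet been measured. It differs from compound 3 in one place: trifluoromethyl in place of chloro on an aromatic carbon. Within the data shown here, the closest precedent is the same swap made on compound 1, where the step of a 1.4-fold higher number from compound 1 to compound 2 (0.16 log units; within the scatter) stayed within the scatter. The other two measured steps compare one phenyl group against another rather than exchanging chloro for trifluoromethyl, so they say less about this particular change. On that basis compound 4 is expected to give a number close to that of compound 3, with the expected step of a 1.4-fold higher number from compound 3 to compound 4 (0.15 log units; within the scatter) not going beyond the scatter in either direction. The estimate for compound 4 in this assay is 3.5 nM, with a range from 1.5 nM to 8 nM.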

Compound 4, inhibition constant: 3.8 nM
Compound 4: the middle estimate sits 1.1-fold (0.04 log units) below what was measured; measured number inside the range.
By their numbers in this assay, from the lowest: compounds 1, 2, 3 and 4 (each within the scatter of the next, the first and the last beyond it).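

In this assay the exchange of chloro for trifluoromethyl can now be read on two different phenyl groups, and the two readings match: the same change on two cores in this assay, a 1.4-fold higher number (0.16 log units; within the scatter) from compound 1 to compound 2 and a 1.5-fold higher number (0.18 log units; within the scatter) from compound 3 to compound 4, 1.1-fold (0.02 log units) apart, within the scatter of two such steps. On the 4-chlorophenyl group, the exchange gives a 1.5-fold higher number from compound 3 to compound 4 (0.18 log units; within the scatter), so neither of the two readings shows this change moving the number beyond the scatter. The place of the group on the phenyl ring makes the larger difference, as the step from the 3-(trifluoromethyl)phenyl group to the 4-(trifluoromethyl)phenyl group gives a 2.9-fold higher number from compound 2 to compound 4 (0.47 log units; beyond the scatter), matching the modest step already seen between the two chlorophenyl compounds, a 2.8-fold higher number from compound 1 to compound 3 (0.44 log units; beyond the scatter), while the change from the 3-chlorophenyl group to the 4-(trifluoromethyl)phenyl group, which alters both place and group, gives a 4.2-fold higher number from compound 1 to compound 4 (0.63 log units; beyond the scatter).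

The compounds shown carry only chloro or trifluoromethyl on this phenyl ring, so they leave open how a methoxy group, a nitrile or an amine would read at either place. From the compounds shown here alone, the rest of the shared core stays the same throughout, so it also remains open whether the small effect of this exchange and the larger effect of its place would persist on a different core.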